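Methoxy to methyl on the pendant aryl of the aminoquinolinol series

The source may report more compounds than this note shows. Statements on the series, on what has been measured and on what is new or still open speak of the compounds shown alone.

Going by the values given here, compound 2 `COc1cccc(C(Nc2ccccn2)c2ccc3cccnc3c2O)c1` stands highest of the two numbers so far: in an assay for inhibition of protein disulfide-isomerase (Homo sapiens), with a stated time of 1 h (a higher number here means a weaker inhibitor, a lower number a stronger inhibitor), compound 2 gives 2860 nM, whereas compound 1 `Oc1cccc(C(Nc2ccccn2)c2ccc3cccnc3c2O)c1Cl` gives 370 nM. Among the compounds with values here, the one measured step, a 7.7-fold higher number from compound 1 to compound 2 (0.89 log units; beyond the scatter), concerns a different replacement of this same aryl and bears only indirectly on the change to compound 3 `Cc1ccc(C(Nc2ccccn2)c2ccc3cccnc3c2O)cc1`, which is 4-methylphenyl in place of 3-methoxyphenyl on a saturated chain carbon bound to an aromatic carbon and a nitrogen on an aromatic ring. Within the data shown here, no measured pair tests removal of the acceptor alone, so the expected step is a 1.2-fold higher number from compound 2 to compound 3 (0.09 log units; within the scatter), within the scatter or slightly weaker. Compound 3 is therefore estimated at 3500 nM, range 1200 nM to 10000 nM.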

Compound 3, half-maximal inhibitory concentration: 460 nM
For compound 3 the middle estimate is 7.6-fold (0.88 log units) above the measured one, and the stated range ends above it.
By their numbers in this assay, from the lowest: compounds 1 and 3 (each within the scatter of the next); then compound 2.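

In this assay, the 4-methylphenyl restores much of what the 3-methoxyphenyl loses (  a 6.2-fold lower number from compound 2 to compound 3 (0.79 log units; beyond the scatter)), so this position does not depend on a hydrogen-bond acceptor on the aryl. It also sits level with the 2-chloro-3-hydroxyphenyl (  a 1.2-fold higher number from compound 1 to compound 3 (0.09 log units; within the scatter)), so neither the hydroxyl nor the chlorine is required for a number of this size.

Substituent and ring position change together in this step. 3-methylphenyl and 4-methoxyphenyl would be needed to separate the two, and an aminomethyl group at this position remains open. No evidence accounts for the recovery.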